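This account rests on a few compounds, and the source may have more. Where it says the series, first, only, none or still open, it means among the compounds named here.

Compound 1 `c1ccc(C2CNCCN2c2ccc3[nH]ncc3c2)cc1`: 200 nM
Compound 2 `c1ccc(CCC2CNCCN2c2ccc3[nH]ncc3c2)cc1`: 31.6 nM

Of the compounds shown here, two have been measured in an assay on HEK293 cells for displacement of a labelled ligand from sodium-dependent dopamine transporter (Homo sapiens), read by scintillation proximity assay; a higher number here means a weaker inhibitor, a lower number a stronger inhibitor. Compound 2 gives 31.6 nM in this assay, the lowest number of the two. Its nearest neighbour is compound 1, which gives 200 nM, and that gap lies beyond the usual scatter of the measurement, so compound 2 is the stronger inhibitor of the pair.

The next compound, compound 3 `CCCCC1CNCCN1c1ccc2[nH]ncc2c1`, shares the core of compound 2 and differs from it in one place: ethyl in place of phenyl on a saturated chain carbon, two bonds along the chain from a saturated ring carbon. The two measured compounds do not contain a change of this kind, so the data do not say which way such a step goes. Within this small set, compound 2 with its longer arm carrying a ring is the one with the lower number in this assay, and losing the ring is expected to cost some of that, giving an expected step of a 3.8-fold higher number from compound 2 to compound 3 (0.58 log units; beyond the scatter) towards a weaker inhibitor. For compound 3 the expected value in this assay is therefore 120 nM, with a range from 40 nM to 400 nM.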

Compound 3, inhibition constant: 31.6 nM
Estimate against measurement, compound 3: 3.8-fold (0.58 log units) above; the whole stated range lies above it.
By their numbers in this assay, from the lowest: compounds 2 and 3 (each within the scatter of the next); then compound 1.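

In this assay, ethyl in place of phenyl on this saturated chain carbon gives no change at the digits printed from compound 2 to compound 3 (within the scatter) and so shows that, for this pair, the six-membered aromatic ring at the end of the arm is not needed to keep the number seen for compound 2. Cut one bond further out, the same difference reads benzyl to propyl, and compound 3 shows that a chain of carbon only, with no ring, can stand at this place without any loss beyond the scatter. The second step, butyl in place of phenyl on a saturated ring carbon, gives a 6.3-fold lower number from compound 1 to compound 3 (0.80 log units; beyond the scatter) and adds that, at that ring carbon, the open butyl chain goes with the stronger inhibitor of the two.

A shorter chain such as methyl, a longer chain such as hexyl, or an amine or a carboxylic acid at the end of the arm would show how much length this place needs and how far it accepts groups other than plain carbon. Nothing available here bears on why phenyl and ethyl read alike at this place.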